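Changing the Aryl Group on the Ring Nitrogen of Compound 3

The compounds below may be only part of what the source reports. "The series", "measured", "known", "first", "only" and "open" are said of these compounds alone.

Measured compounds:
compound 1, `N#CC1=C(N)Oc2c(c3nc4ccccc4nc3c3ccccc23)C12C(=O)N(Cc1cnnn1-c1ccc(N)cc1)c1ccccc12`, > 50000 nM in a functional assay on HepG2 cells (Homo sapiens) for antiproliferative activity, read by MTT assay, with a stated time of 48 h; on this read-out lower numbers stand for stronger inhibition and higher numbers for weaker inhibition (a limit of the assay)
compound 2, `Cc1ccc(-n2nncc2CN2C(=O)C3(C(C#N)=C(N)Oc4c3c3nc5ccccc5nc3c3ccccc43)c3ccccc32)cc1C`, > 50000 nM (a limit of the assay)
compound 3, `Cc1ccccc1-n1nncc1CN1C(=O)C2(C(C#N)=C(N)Oc3c(N)cc4nc5ccccc5nc4c32)c2ccccc21`, > 50000 nM (a limit of the assay)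

Compound 3 stands at the limit of this assay, as the shown numbers put it; the value of compound 3 is a limit and not a number. Two further values shown are limits as well. Among the measured compounds shown here, the only single-point change among the measured compounds, a step that the two limits leave unreadable from compound 1 to compound 2, is not readable, because of the limit of > 50000 nM in this assay, at which 3 of the 3 values shown sit. Compound 4, `CCOc1ccc(-n2nncc2CN2C(=O)C3(C(C#N)=C(N)Oc4c(N)cc5nc6ccccc6nc5c43)c3ccccc32)cc1`, differs from compound 3 by 4-ethoxyphenyl in place of 2-methylphenyl on an aromatic nitrogen. For the measured compounds named here, no measured step tells the size of such a change; the measured compounds only show that all sit at the limit. No shift beyond the scatter is therefore expected for compound 4, and the estimated step is a step that the limit leaves unreadable from compound 3 to compound 4. Compound 4 is expected to give about 60000 nM, in the range 15000 nM to 200000 nM, most likely reported as a limit again.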

Compound 4, half-maximal inhibitory concentration: > 50000 nM
Compound 4 was reported as a limit; the forecaster's own chance of this, stated with the estimate: 85%; the middle value is on the limit's open side.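

No step can be read from compound 3 to compound 4, since both values are limits of the assay: the limit of > 50000 nM in this assay, at which 4 of the 4 values shown sit. The compounds shown leave open whether any change of the aryl group on the aromatic nitrogen shifts the result in this assay at all.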